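The source may report more compounds than this note shows. Statements on the series, on what has been measured and on what is new or still open speak of the compounds shown alone.

Compound 1, `CCCCCCCCNC(=N)NC(=N)Nc1ccc(Cl)cc1`, gives 5.13 in a physicochemical assay for lipophilicity, in phosphate buffer, measured as octanol-water partition, at pH 11.5; a higher number here means a more lipophilic compound, a lower number a more polar compound.
Compound 2, `CCCCCCCCNC(=N)NC(=N)Nc1ccc(C(F)(F)F)cc1`, gives 5.31 in this assay.

Among the two measured numbers, compound 1 stands lowest in this assay, and its nearest neighbour is compound 2, the step of a number 0.18 log units higher from compound 1 to compound 2 (within the scatter) lying within the scatter of the measurement. Going by the values given here, that single step, trifluoromethyl in place of chloro on an aromatic carbon, is the only measured comparison available.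

Compound 3, `CCNC(=N)NC(=N)Nc1ccc(Cl)cc1`, has not yet been measured. It differs from compound 1 in that (hydrogen in place of hexyl on a saturated chain carbon, two bonds along the chain from an amine nitrogen). Among the compounds with values here, the one measured step concerns the aromatic substituent and leaves the saturated chain untouched, so it does not bear on this change; no measured pair speaks to the shortening of the chain from octyl to ethyl. The change removes hexyl, six carbon atoms of saturated chain, from the only part of the molecule that is not shared by both compounds, and in this assay such a loss is expected to register as a large drop. Compound 3 is therefore estimated at 2.1, within 1.4 to 2.8, a step of a number 3.03 log units lower from compound 1 to compound 3 (beyond the scatter) expected from compound 1.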

Compound 3, partition coefficient: 2.14
Compound 3: middle estimate off by 0.04 log units, on the low side; measured number inside the range.
By their numbers in this assay, from the lowest: compound 3; then compounds 1 and 2 (each within the scatter of the next).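

Going by these compounds alone, the chain is where a single change first moves the number beyond the scatter: hydrogen in place of hexyl, on a saturated chain carbon, two bonds along the chain from an amine nitrogen, gives a number 2.99 log units lower from compound 1 to compound 3 (beyond the scatter) in this assay, whereas the only earlier step, at the aromatic carbon, was a number 0.18 log units higher from compound 1 to compound 2 (within the scatter). The part that leaves has 6 carbon atoms, no ring, no hydrogen-bond donors or acceptors and no net charge. The rest of the core of compound 1 is unchanged in compound 3. No measurement offered here gives a reason for the size of this step.

On these data alone, two chain lengths cannot show how the number moves along the series: whether a butyl or hexyl chain would fall evenly between ethyl and octyl, and whether a longer chain such as dodecyl would carry on the same trend, stays open. Also open, as far as these compounds go, is whether the step from chloro to trifluoromethyl would look the same on the ethyl chain, and what a hydroxyl group or an amine carried on the chain would do in this assay.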